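The source may hold more compounds than are shown below. What is called first, only, known or untested is meant among the compounds shown, and "the series" means these compounds.

Compound 1, `COc1ccc(-c2cc(C(=O)Nc3nc4ccc(Cl)cc4s3)nc3cc(-c4ccccc4)nn23)cc1OC`, gives 9330 nM.
Compound 2, `COc1ccc(-c2cc(C(=O)Nc3nc4ccc(F)cc4s3)nc3cc(-c4ccccc4)nn23)cc1OC`, gives 18600 nM.
Compound 3, `COc1ccc(-c2cc(C(=O)Nc3nc4ccccc4s3)nc3cc(-c4ccccc4)nn23)cc1OC`, gives 19100 nM.

These numbers come from a functional assay on DU-145 cells (Homo sapiens) for cytotoxicity, read by MTT assay, with a stated time of 48 h; on this read-out higher numbers stand for weaker inhibition and lower numbers for stronger inhibition. Compound 3 stands apart only from compound 1, with a 2.0-fold higher number from compound 1 to compound 3 (0.31 log units; beyond the scatter); against compound 2 the step is a 1.0-fold higher number from compound 2 to compound 3 (0.01 log units; within the scatter) and so tells nothing. Compound 4, `COc1ccc(-c2cc(C(=O)Nc3nc4cc(C)c(C)cc4s3)nc3cc(-c4ccccc4)nn23)cc1OC`, is reached by 5,6-dimethyl-1,3-benzothiazol-2-yl in place of 1,3-benzothiazol-2-yl on an amide-type nitrogen. Going by the values given here, the steps that bear on this are the earlier changes at the same ring, a 2.0-fold higher number from compound 1 to compound 2 (0.30 log units; within the scatter) and a 2.0-fold higher number from compound 1 to compound 3 (0.31 log units; beyond the scatter), both small, and no measured step involves methyl groups. So only a modest change in this assay is expected, if any, most likely toward a somewhat lower number. Compound 4 is therefore expected at about 12000 nM, within 5000 nM to 30000 nM, which would mean an estimated step of a 1.6-fold lower number from compound 3 to compound 4 (0.20 log units; within the scatter).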

Compound 4, half-maximal inhibitory concentration: 6910 nM
Compound 4: middle estimate off by 1.7-fold (0.24 log units), on the high side; the measured number falls inside the stated range.
By their numbers in this assay, from the lowest: compounds 4, 1, 2 and 3 (each within the scatter of the next, the first and the last beyond it).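

Swapping in 5,6-dimethyl-1,3-benzothiazol-2-yl gives a clear drop in this assay against the unsubstituted group (a 2.8-fold lower number from compound 3 to compound 4 (0.44 log units; beyond the scatter)) and against the 6-fluoro group (a 2.7-fold lower number from compound 2 to compound 4 (0.43 log units; beyond the scatter)). Against the 6-chloro group, the change stays inside the scatter (a 1.4-fold lower number from compound 1 to compound 4 (0.13 log units; within the scatter)), so these two groups cannot be ranked, and both stand clearly below the unsubstituted group. Nothing available explains why the number falls. From the compounds shown here alone, whether a single methyl would be enough remains open. So does the effect of a methoxy group or an amine on this ring.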